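The compounds below may be only part of what the source reports. "The series", "measured", "known", "first", "only" and "open" are said of these compounds alone.

In a functional assay on SK-BR-3 cells (Homo sapiens) for antiproliferative activity, read by MTT assay, with a stated time of 72 h (a higher number here means a weaker inhibitor, a lower number a stronger inhibitor), the measured compounds stand as follows:
compound 1 `Cc1cc(N2CCN(C(C)C)CC2)nc2ccc(NC(=O)c3ccc(Cl)c(Cl)c3)cc12` gives 6680 nM
compound 2 `Cc1cc(NCCN2CCCC2)nc2ccc(NC(=O)c3ccc(Cl)c(Cl)c3)cc12` gives 9530 nM

Compound 2 sits alongside compound 1: a 1.4-fold higher number from compound 1 to compound 2 (0.15 log units; within the scatter), so the two are not separated. Compound 3 `CNc1cc(C)c2cc(NC(=O)c3ccc(Cl)c(Cl)c3)ccc2n1` differs from compound 2 by hydrogen in place of (pyrrolidin-1-yl)methyl on a saturated chain carbon bound to a nitrogen on an aromatic ring. For the measured compounds named here, the single measured step exchanged one amine-bearing group for another and stayed within the scatter; it does not speak to removing the group outright, so no measured step bears directly on this change. With nothing to anchor a direction, a step no larger than a modest weakening is expected, a 1.6-fold higher number from compound 2 to compound 3 (0.20 log units; within the scatter). Compound 3 is thus estimated at 15000 nM, in the range 5000 nM to 45000 nM.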

Compound 3, half-maximal inhibitory concentration: 6350 nM
For compound 3 the middle estimate is 2.4-fold (0.37 log units) above the measured one, within the range that was stated.
By their numbers in this assay, from the lowest: compounds 3, 1 and 2 (each within the scatter of the next).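

In this assay, the loss of the (pyrrolidin-1-yl)methyl group gives a 1.5-fold lower number from compound 2 to compound 3 (0.18 log units; within the scatter). Methylamino in place of 4-isopropylpiperazin-1-yl gives a 1.1-fold lower number from compound 1 to compound 3 (0.02 log units; within the scatter). On this aromatic carbon, compound 1, compound 2 and compound 3 are therefore not separated, whether the substituent carries a saturated amine ring or only methylamino. No measurement offered here accounts for this flat result. Open, as far as these compounds go, is whether an unsubstituted amino group, a carboxylic acid or a longer chain at this carbon would stand apart from these three. Also open, from the compounds shown here alone, is whether changes elsewhere on the shared core would do so.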